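The source may report more compounds than this note shows. Statements on the series, on what has been measured and on what is new or still open speak of the compounds shown alone.

Of the compounds shown here, two have been measured in a functional assay on cells for antagonist activity at C-X-C chemokine receptor type 4 (Homo sapiens), read by fluorescence and calcium flux, with stated times of 25 min and 90 s; on this read-out higher numbers stand for weaker inhibition and lower numbers for stronger inhibition. Compound 1 `c1ccc2c(c1)CN[C@@H](CN(CCCCNCC1CCCCC1)[C@H]1CCCc3cccnc31)C2` gives 158 nM. Among the measured compounds shown here, compound 2 `O=S1(=O)CCC(NCCCCN(C[C@H]2Cc3ccccc3CN2)[C@H]2CCCc3cccnc32)CC1` gives 45.5 nM; the one structural change behind these two numbers, a 3.5-fold lower number from compound 1 to compound 2 (0.54 log units; beyond the scatter), is the only measured step available. On the numbers shown, compound 2 stands lowest of the two, with compound 1 as its only neighbour.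

Compound 3 `CC(C)(N)CCCN(C[C@H]1Cc2ccccc2CN1)[C@H]1CCCc2cccnc21` is not yet measured. It differs from compound 2 in a group of 4 heavy atoms (3 carbon, 1 nitrogen; no ring) in place of a group of 10 heavy atoms (6 carbon, 1 nitrogen, 2 oxygen, 1 sulfur; one six-membered non-aromatic ring with 1 hetero atom), on a saturated chain carbon, three bonds along the chain from an amine nitrogen. The step from compound 1 to compound 2 altered the same end of the same chain and was modest in size, but it exchanged one ring for another, whereas here the ring leaves altogether and a much smaller group arrives. For the measured compounds named here, no measured step covers that kind of exchange, so the outcome is uncertain. The expectation is therefore a step of a 1.8-fold higher number from compound 2 to compound 3 (0.25 log units; within the scatter) in this assay, leaning toward a somewhat higher number than compound 2. Compound 3 is estimated at 80 nM, within a range from 25 nM to 250 nM.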

Compound 3, half-maximal inhibitory concentration: 24.6 nM
Estimate against measurement, compound 3: 3.3-fold (0.51 log units) above; measured number outside the range, below it.
By their numbers in this assay, from the lowest: compounds 3 and 2 (each within the scatter of the next); then compound 1.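

In this assay, the step of a 1.8-fold lower number from compound 2 to compound 3 (0.27 log units; within the scatter) lies within the usual scatter, so on a saturated chain carbon, three bonds along the chain from an amine nitrogen, the large group with its six-membered ring and the small 1-amino-1-methylethyl group cannot be told apart, which shows that a ring at this end of the chain is not required for a number at this level. The step of a 6.4-fold lower number from compound 1 to compound 3 (0.81 log units; beyond the scatter) lies beyond the scatter, so compound 3, with no ring at this end, stands clearly apart from compound 1, which carries ((cyclohexylmethyl)amino)methyl in the same place. Nothing measured here explains why these groups give these numbers.

The compounds shown leave open whether the two methyl groups of 1-amino-1-methylethyl matter, which a plain aminomethyl group in the same place would test. They also leave open whether the amine itself counts, as a hydroxyl group or a carboxylic acid in its place would show, and how a longer chain carrying the same amine would read in this assay.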